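Thiophene acrylamide replacing bromothienylmethyl on a quinazoline-type amine

The source may report more compounds than this note shows. Statements on the series, on what has been measured and on what is new or still open speak of the compounds shown alone.

Compound 1 `Clc1cccc(Nc2ncnc3ccc(NCc4ccc(Br)s4)cc23)c1` gives the lowest number of the three measured compounds in a functional assay on HepG2 cells (Homo sapiens) for antiproliferative activity, read by MTT assay, with a stated time of 48 h (on this read-out lower numbers stand for stronger inhibition and higher numbers for weaker inhibition), with 3110 nM. Compound 2 `Clc1cccc(Nc2ncnc3ccc(NCc4c[nH]c5ccccc45)cc23)c1` gives 5260 nM in this assay, and the step of a 1.7-fold higher number from compound 1 to compound 2 (0.23 log units; within the scatter) stays within the scatter. Among the measured compounds shown here, compound 3 `O=C(/C=C/c1cccnc1)Nc1ccc2ncnc(Nc3cccc(Cl)c3)c2c1` gives 9120 nM in this assay; its number is higher than that of compound 1, and the gap lies beyond the scatter, although no single-point step between these two is defined.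

Compound 4 `O=C(/C=C/c1cccs1)Nc1ccc2ncnc(Nc3cccc(Cl)c3)c2c1` differs from compound 1 by (2-(thiophen-2-yl)ethenyl)carbonyl in place of (5-bromothiophen-2-yl)methyl on a nitrogen on an aromatic ring. For the measured compounds named here, no measured step changes the group on that nitrogen in the same way; the only measured step, from compound 1 to compound 2, swaps one ring for another while keeping the saturated chain carbon, and it was within the scatter. Compound 3 carries a closely related ethenylcarbonyl linker and gives the highest number shown, so a weakening step in this assay is expected for compound 4, estimated as a 2.3-fold higher number from compound 1 to compound 4 (0.35 log units; beyond the scatter). Compound 4 is therefore expected to give about 7000 nM in this assay, within a range from 2500 nM to 20000 nM.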

Compound 4, half-maximal inhibitory concentration: 10400 nM
The estimate for compound 4 lay 1.5-fold (0.17 log units) below the measured number, within the range that was stated.
By their numbers in this assay, from the lowest: compounds 1, 2, 3 and 4 (each within the scatter of the next, the first and the last beyond it).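

In this assay the (2-(thiophen-2-yl)ethenyl)carbonyl in place of (5-bromothiophen-2-yl)methyl on the nitrogen gives a 3.3-fold higher number from compound 1 to compound 4 (0.52 log units; beyond the scatter) and so reaches beyond the scatter, while the ring swap on the saturated chain carbon, a 1.7-fold higher number from compound 1 to compound 2 (0.23 log units; within the scatter), stayed within it. With the ethenylcarbonyl linker kept, thiophen-2-yl in place of pyridin-3-yl gives a 1.1-fold higher number from compound 3 to compound 4 (0.06 log units; within the scatter), so these two rings are not told apart on that linker. Nothing at hand accounts for the step from the saturated chain carbon to the carbonyl linker.

The compounds shown leave open whether that step belongs to the carbonyl, to the double bond or to the loss of the bromine. A saturated propanoyl chain carrying the thiophene, or a 5-bromothiophen-2-yl on the same ethenylcarbonyl linker, would separate these.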